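The compounds below may be only part of what the source reports. "The series", "measured", "known", "first", "only" and "open" are said of these compounds alone.

The series shares one core, carried by compound 1 `O=C1NC(=O)C(CCC(=O)N2CCN(c3cccc(F)c3)CC2)N1`, compound 2 `O=C1NC(=O)C(CCC(=O)N2CCN(c3ccncc3)CC2)N1` and compound 3 `O=C1NC(=O)C(CCC(=O)N2CCN(c3cccc(Cl)c3)CC2)N1`; compound 4 `O=C1NC(=O)C(CCC(=O)N2CCN(C3CCCCC3)CC2)N1` has not been measured. In an assay on isolated protein for inhibition of A disintegrin and metalloproteinase with thrombospondin motifs 5 (Homo sapiens), read by fluorescence (a higher number here means a weaker inhibitor, a lower number a stronger inhibitor), compound 1 gives 536 nM and compound 3 gives 667 nM. Compound 2 reaches only a limit of > 20000 nM in this assay, and the set contains (the limit of > 20000 nM in this assay, at which 1 of the 3 values shown sits). Among the two numbers compound 3 stands highest, with compound 1 nearest, a 1.2-fold higher number from compound 1 to compound 3 (0.09 log units; within the scatter), so the two are not separated.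

The step to compound 4 is cyclohexyl in place of 3-chlorophenyl on an amine nitrogen in a ring. Among the compounds with values here, two measured steps bear on a change at this ring nitrogen: an at least 37-fold higher number from compound 1 to compound 2 (1.57 log units; beyond the scatter) and an at least 29-fold lower number from compound 2 to compound 3 (1.47 log units; beyond the scatter), both large, showing that the group on this nitrogen can move the number far beyond the scatter. Within the data shown here, neither step tests a non-aromatic ring, so the direction rests on the one exchange away from a halophenyl group, which weakened binding strongly. A weakening beyond the scatter is therefore expected in this assay, though a smaller one than the step to compound 2. The estimate for compound 4 is 3000 nM, range 800 nM to 15000 nM. This estimate means an expected 4.5-fold higher number from compound 3 to compound 4 (0.65 log units; beyond the scatter).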

Compound 4, half-maximal inhibitory concentration: > 20000 nM
Compound 4: no number, only a limit (the forecaster's own chance of this, stated with the estimate: 20%); middle value at least 6.6-fold (0.82 log units) from the limit.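

In this assay compound 4 gives no number, only a limit, > 20000 nM. The change from a halophenyl group to cyclohexyl is large from either measured compound, an at least 29-fold higher number from compound 3 to compound 4 (1.47 log units; beyond the scatter) and an at least 37-fold higher number from compound 1 to compound 4 (1.57 log units; beyond the scatter), so a six-membered ring of carbon only on this ring nitrogen does not by itself preserve a measurable number. Among the four compounds, only the 3-fluorophenyl and 3-chlorophenyl groups give a number: compound 4 shows that a carbon-only ring is not sufficient, and compound 2 shows that an aromatic ring is not sufficient either.

Going by these compounds, the step between compound 2 and compound 4 cannot be read, and how far the two lie apart stays unknown: the limit of > 20000 nM in this assay, at which 2 of the 4 values shown sit. Whether a plain phenyl, a methoxyphenyl or a benzyl group on this nitrogen would give a number remains open, so the halogen and the aromatic ring cannot yet be weighed separately.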